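The compounds below may be only part of what the source reports. "The series", "measured", "known", "first", "only" and "open" are said of these compounds alone.

Measured compounds:
- Compound 1 `N#Cc1ccc(Nc2nccc(Oc3ccc(-c4ccc(C#N)cc4)cc3F)n2)cc1` — in a functional assay on MT4 cells (Homo sapiens) for cytotoxicity, read by MTT assay, with a stated time of 5 days (on this read-out lower numbers stand for higher toxicity in this test and higher numbers for lower toxicity in this test), compound 1 gives > 307000 nM, which is a limit of the assay and not a number.
- Compound 2 `N#Cc1ccc(Nc2nccc(Oc3ccc(-c4ccc(C#N)cc4)c(F)c3F)n2)cc1` — in this assay compound 2 gives > 294000 nM, also a limit of the assay.
- Compound 3 `Cc1cc(-c2ccc(C#N)cc2)c(Cl)cc1Oc1ccnc(Nc2ccc(C#N)cc2)n1` — in this assay compound 3 gives > 285000 nM, again a limit of the assay.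

All three measured compounds share one core and stop at a limit, so compound 2 cannot be placed above or below the others; every value shown is a limit, as the limit of > 285000 nM in this assay, at which 1 of the 3 values shown sits, the limit of > 294000 nM in this assay, at which 1 of the 3 values shown sits, and the limit of > 307000 nM in this assay, at which 1 of the 3 values shown sits, record. Going by the values given here, the only single-change step among them, a step that the two limits leave unreadable from compound 1 to compound 2, is unreadable because both ends are limits.

Compound 4 `N#Cc1ccc(Nc2nccc(Oc3ccc(-c4ccc(C#N)cc4)c(F)c3)n2)cc1` is the compound not yet measured. Its change from compound 2 is hydrogen in place of fluoro on an aromatic carbon. This is the reverse of the change from compound 1 to compound 2, whose step size could not be read, so no direction and no size beyond the scatter can be expected for the step that the limit leaves unreadable from compound 2 to compound 4, which is itself an expectation only. Compound 4 is therefore expected to give about 300000 nM in this assay, with a range from 150000 nM to 600000 nM, most likely reported as a limit.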

Compound 4, half-maximal cytotoxic concentration: > 307000 nM
Compound 4 gave a limit, no number; the forecaster's own chance of this, stated with the estimate: 90%; middle value at least 1.0-fold (0.01 log units) away from the limit.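

Going by these compounds alone, compound 2 and compound 4 both stop at a limit of the assay and not at a number, so no step between them can be read. The compounds shown leave open what concentration of any of them would reach the half-maximal cytotoxic effect in this assay, and whether hydrogen in place of fluoro changes it.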